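Methoxycarbonyl Out, Pentyl In: A Partition Forecast

A few compounds are considered here, and "the series" means these few. Any claim that something is new, unique, unknown or untested is made for them only; others in the source may bear on it.

Measured so far in a physicochemical assay for lipophilicity, measured as octanol-water partition; on this read-out lower numbers stand for lower lipophilicity and higher numbers for higher lipophilicity:
- compound 1 `CC(C)=CCC/C(C)=C/CC/C(C)=C/Cn1cc(-c2ccccc2)nn1` gives 6.95
- compound 2 `CCCCCc1cn(C/C=C(/C)CC/C=C(\C)CCC=C(C)C)nn1` gives 7.5
- compound 3 `COC(=O)c1cn(C/C=C(\C)CC/C=C(\C)CCC=C(C)C)nn1` gives 5.25

Of these three, compound 3 has the lowest number at 5.25 on this scale, and the other two lie above it by more than the scatter. Still unmeasured is compound 4 `CCCCCc1cn(C/C=C(\C)CC/C=C(\C)CCC=C(C)C)nn1`, which carries pentyl in place of methoxycarbonyl on an aromatic carbon. Within the data shown here, only one measured step involves the group that leaves: it is a number 1.70 log units lower from compound 1 to compound 3 (beyond the scatter) with methoxycarbonyl in place of phenyl on an aromatic carbon. That large step ends at methoxycarbonyl, which suggests that exchanging this group can shift the number substantially. The closest guide to the new group is compound 2 with 7.5 as its value, since compound 2 also carries pentyl. In this assay a large rise is therefore expected, estimated as a number 2.25 log units higher from compound 3 to compound 4 (beyond the scatter) and well beyond the scatter. Compound 4 is estimated to read 7.5 with an expected range from 7.1 to 7.9 when measured.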

Compound 4, partition coefficient: 7.5
Beside the measured number, compound 4's estimate shows no gap at the digits printed; low and high end bracket the measured number.
By their numbers in this assay, from the lowest: compound 3; then compound 1; then compounds 2 and 4 (each within the scatter of the next).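

In this assay, pentyl in place of methoxycarbonyl on this aromatic carbon gives a number 2.25 log units higher from compound 3 to compound 4 (beyond the scatter), the largest step seen so far at this position. Pentyl in place of phenyl gives a number 0.55 log units higher from compound 1 to compound 4 (beyond the scatter), so the three groups now form an order with every gap beyond the scatter: methoxycarbonyl lowest, then phenyl, then pentyl. Changing how one double bond in the chain is drawn gives no change at the digits printed from compound 2 to compound 4 (within the scatter), and this pair tests that double bond alone because of a single point: the fact that compounds 2 and 4 differ only in the configuration as drawn

The compounds shown leave open how an amine or a carboxylic acid on this aromatic carbon would read, and whether a longer chain would read higher than pentyl or no differently. They also leave open whether the second double bond of the chain, which is drawn the same way in compound 2 and compound 4, would matter as little if its drawn configuration changed.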